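The compounds below may be only part of what the source reports. "The series", "measured", "known", "first", "only" and "open" are said of these compounds alone.

Among the measured compounds shown here, compound 1 `Cc1cnc(Nc2ccc(S(N)(=O)=O)cc2)nc1Nc1nc2ccccc2s1` is the only member of the series with a number in a functional assay on MDA-MB-231 cells (Homo sapiens) for antiproliferative activity, read by MTT assay, with a stated time of 48 h; a higher number here means a weaker inhibitor, a lower number a stronger inhibitor: compound 1 gives 16800 nM. Compound 2 `Cc1cnc(Nc2ccc(F)cc2)nc1Nc1nc2ccccc2s1` carries a limit of the assay rather than a number, as compound 2 gives > 50000 nM in this assay. The step of an at least 2.9-fold higher number from compound 1 to compound 2 (0.47 log units; beyond the scatter) rests on that limit (the limit of > 50000 nM in this assay, at which 1 of the 2 values shown sits). For the measured compounds named here, compound 3 `NS(=O)(=O)c1ccc(Nc2nccc(Nc3nc4ccccc4s3)n2)cc1` differs from compound 1 by hydrogen in place of methyl on an aromatic carbon, a change at a different place from the one measured step, so no measured step bears on it directly. The expectation for compound 3 is a step of a 1.1-fold lower number from compound 1 to compound 3 (0.02 log units; within the scatter), none beyond the scatter, and an estimated value of 16000 nM (range 5000 nM to 50000 nM).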

Compound 3, half-maximal inhibitory concentration: 5000 nM
Beside the measured number, compound 3's estimate is 3.2-fold (0.51 log units) above it, within the range that was stated.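

With hydrogen in place of methyl on this aromatic carbon, the series shows a 3.4-fold lower number from compound 1 to compound 3 (0.53 log units; beyond the scatter) in this assay, so the methyl of compound 1 is not needed for the activity seen here, and this position also moves the number. Among the compounds shown here, until now, the only change read was fluoro in place of sulfamoyl, and that step rested on a limit. Nothing given offers a reason for the new step.

As far as these compounds go, whether chloro, ethyl, methoxy or an amine on this carbon would move the number in either direction remains open. Also open, from the compounds shown here alone, is whether hydrogen in place of methyl gives a similar step when fluoro stands in place of sulfamoyl.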